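Recovering potency at the propyl position of compound 2

The source may report more compounds than this note shows. Statements on the series, on what has been measured and on what is new or still open speak of the compounds shown alone.

Values in a functional assay on MCF7 cells (Homo sapiens) for cytotoxicity, read by WST assay, with a stated time of 72 h (on this read-out higher numbers stand for weaker inhibition and lower numbers for stronger inhibition), are as follows
Compound 1 `CCOc1ccc(C2(c3ccc(O)cc3)C(=O)Nc3c2ccc(F)c3F)cc1` gives 11 nM
Compound 2 `CCCC1(c2ccc(O)cc2)C(=O)Nc2c1ccc(F)c2F` gives > 1000 nM (a limit)
Compound 3 `O=C1Nc2c(ccc(F)c2F)C1(c1ccc(O)cc1)C1CCCCCC1` is not yet measured

Compound 2 has no number, only a limit (in this assay it reads > 1000 nM) and so stands at the limit of > 1000 nM in this assay, at which 1 of the 2 values shown sits (no exact position can be given).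

The next change is cycloheptyl in place of propyl on a saturated ring carbon. Going by the values given here, one measured step bears on this carbon: an at least 90-fold higher number from compound 1 to compound 2 (1.95 log units; beyond the scatter) (large, beyond the scatter), with propyl in place of 4-ethoxyphenyl. Compound 3 again carries a ring there, as compound 1 does, although a non-aromatic one of carbon only. With this single step as a guide, part of that loss is expected to return, so a large move toward stronger inhibition is expected, with wide uncertainty. The expected step is an at least 16-fold lower number from compound 2 to compound 3 (1.22 log units; beyond the scatter) (an estimate measured from a limit). For compound 3 the estimated value is 60 nM (expected range 8 nM to 500 nM).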

Compound 3, half-maximal inhibitory concentration: 1.2 nM
For compound 3 the middle estimate is 50-fold (1.70 log units) above the measured one; measured number outside the range, below it.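

In this assay, cycloheptyl on the saturated ring carbon gives an at least 830-fold lower number from compound 2 to compound 3 (2.92 log units; beyond the scatter), so the change does more than undo the loss seen with propyl at this position. Set against 4-ethoxyphenyl on the same carbon, cycloheptyl gives a 9.2-fold lower number from compound 1 to compound 3 (0.96 log units; beyond the scatter), so among these three compounds an aromatic ring is not needed here, and a seven-membered non-aromatic ring of carbon only goes further than the 4-ethoxyphenyl group of compound 1. Compound 2 stands only as a limit, so the step from it has a bound and no exact size: the limit of > 1000 nM in this assay, at which 1 of the 3 values shown sits.

Propyl and cycloheptyl differ both in the presence of a ring and in the count of carbon atoms, so the compounds shown do not separate these two changes, and a straight heptyl chain on this carbon would do so. Also open, as far as these compounds go, is how far the result depends on ring size and ring atoms, for example whether cyclopentyl or a piperidinyl ring, which brings in a nitrogen, would keep the strong inhibition of compound 3.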